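Working notes on a small antiproliferative series

This account rests on a few compounds, and the source may have more. Where it says the series, first, only, none or still open, it means among the compounds named here.

Measured so far:
compound 1 `NC(=O)c1c(NC(=O)c2ccccc2Cl)sc2c1CCN(C(=S)Nc1ccccc1C(F)(F)F)C2` gives 26700 nM in a functional assay on HeLa cells (Homo sapiens) for antiproliferative activity, with a stated time of 24 h; on this read-out higher numbers stand for weaker inhibition and lower numbers for stronger inhibition
compound 2 `Cc1ccccc1NC(=S)N1CCc2c(sc(NC(=O)c3ccccc3Cl)c2C(N)=O)C1` reaches only a limit, > 50000 nM
compound 3 `NC(=O)c1c(NC(=O)c2ccc(C(F)(F)F)cc2)sc2c1CCN(C(=S)Nc1cc(C(F)(F)F)cc(C(F)(F)F)c1)C2` gives 49000 nM

Compound 2 differs from compound 1 by methyl in place of trifluoromethyl on an aromatic carbon. This step, an at least 1.8-fold higher number from compound 1 to compound 2 (0.27 log units; that floor lies within the scatter), is bounded by the limit of > 50000 nM in this assay, at which 1 of the 3 values shown sits. Compound 3 and compound 1 lie within the usual scatter of each other; the difference between the two cores is not broken down here.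

Compound 4 `Cc1ccc(C(=O)Nc2sc3c(c2C(N)=O)CCN(C(=S)Nc2cc(C(F)(F)F)cc(C(F)(F)F)c2)C3)cc1` differs from compound 3 by methyl in place of trifluoromethyl on an aromatic carbon. The place differs: ortho to a large group in the first pair, para to a large group here, so it is the same kind of change, not the same. The expected step is a 1.2-fold higher number from compound 3 to compound 4 (0.09 log units; within the scatter), resting on compound 1 and an at least 1.8-fold higher number from compound 1 to compound 2 (0.27 log units; that floor lies within the scatter). Compound 4 is expected at 60000 nM, between 30000 nM and 120000 nM, with a limit likely.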

Compound 4, half-maximal inhibitory concentration: 17100 nM
Compound 4: the middle estimate sits 3.5-fold (0.55 log units) above what was measured, outside the stated range (below it).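

In this assay, methyl in place of trifluoromethyl does not carry over as one fixed step between these two cores, and the new step, a 2.9-fold lower number from compound 3 to compound 4 (0.46 log units; beyond the scatter), does not match the earlier one: the same change on two cores in this assay, an at least 1.8-fold higher number (0.27 log units; that floor lies within the scatter) from compound 1 to compound 2 and a 2.9-fold lower number (0.46 log units; beyond the scatter) from compound 3 to compound 4, at least 5.3-fold (0.72 log units) apart, beyond the scatter of two such steps. Compound 2 stands at a limit, so the earlier step is known only as a floor: the limit of > 50000 nM in this assay, at which 1 of the 4 values shown sits. Among the compounds shown here, with only two pairs, this does not show what sets the gap, and the place of the change also differs between them.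

Open, from the compounds shown here alone, is how a methoxy group, a nitrile or an amine would read in place of methyl, para to a large group. Also open, going by these compounds, is whether either step holds on a third core.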